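A few compounds are considered here, and "the series" means these few. Any claim that something is new, unique, unknown or untested is made for them only; others in the source may bear on it.

Compound 1 is `O=C1N=C(N2CCC[C@H]2C(=O)Nc2ccc3ncnc(Nc4cccc(Cl)c4)c3c2)S/C1=C/c1ccccc1Cl`; in a functional assay on A549 cells (Homo sapiens) for antiproliferative activity, read by MTT assay (a lower number here means a stronger inhibitor, a higher number a weaker inhibitor), compound 1 gives > 50000 nM, which is a limit of the assay and not a number.
Compound 2 is `COc1ccccc1/C=C1/SC(N2CCC[C@H]2C(=O)Nc2ccc3ncnc(Nc4cccc(Cl)c4)c3c2)=NC1=O`; in this assay compound 2 gives > 50000 nM, again a limit rather than a number.

Compound 1 therefore stands at the edge of what this assay can report: both values shown sit at the limit of > 50000 nM in this assay, at which 2 of the 2 values shown sit, so no ranking of the two is possible. Going by the values given here, the only measured step, a step that the two limits leave unreadable from compound 1 to compound 2, carries [methoxy in place of chloro on an aromatic carbon] and cannot be sized, since both ends are limits.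

Compound 3 is `O=C1N=C(N2CCC[C@H]2C(=O)Nc2ccc3ncnc(Nc4cccc(Cl)c4)c3c2)S/C1=C/c1ccc2ccccc2n1`. It differs from compound 1 by quinolin-2-yl in place of 2-chlorophenyl on a double-bonded chain carbon bound to a double-bonded ring carbon. Among the compounds with values here, no measured step touches this part of the molecule, and the one step that is measured is unreadable, so there is nothing to anchor a direction for this assay. With compound 1 at its limit, the step of a number no higher from compound 1 to compound 3 (the limit leaves the size open) is expected to leave compound 3 at or near that same limit. Compound 3 is therefore estimated at 50000 nM, with a range from 8000 nM to 300000 nM.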

Compound 3, half-maximal inhibitory concentration: > 50000 nM
Compound 3: no number, only a limit (the forecaster's own chance of this, stated with the estimate: 70%); the middle value lies on the limit itself.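

Compound 3 joins compound 1 and compound 2 at a limit of the assay, so no step among these three compounds can be read, and none can be given a size. All three values sit at one limit: the limit of > 50000 nM in this assay, at which 3 of the 3 values shown sit.

What the compounds shown leave open is whether any change at this place on the shared core can bring a measurable number in this assay.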